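From 3-nitrophenyl to 4-nitrophenyl on compound 2

A few compounds are considered here, and "the series" means these few. Any claim that something is new, unique, unknown or untested is made for them only; others in the source may bear on it.

Compound 1 `CCCCCOc1ccc(C(=O)N(C(=S)OCCN2C(=O)c3ccccc3C2=O)c2ccc(F)cc2)cc1`: > 100000 nM (a limit)
Compound 2 `O=C1c2ccccc2C(=O)N1CCOC(=S)N(C(=O)c1cccc([N+](=O)[O-])c1)c1ccc(Cl)cc1`: 18000 nM

Both compounds were tested in an ADME assay on MT4 cells (Homo sapiens) for cytotoxicity, read by MTT assay; a higher number here means that more compound is tolerated, a lower number that less compound is tolerated. For compound 1, the entry > 100000 nM is a limit of the assay and not a number. Within the data shown here, that leaves compound 2, at 18000 nM, as the only true number so far.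

Compound 3 `O=C1c2ccccc2C(=O)N1CCOC(=S)N(C(=O)c1ccc([N+](=O)[O-])cc1)c1ccc(Cl)cc1` has the same atoms as compound 2, joined differently: 4-nitrophenyl in place of 3-nitrophenyl on a carbonyl carbon. Here 4-nitrophenyl stands in place of 3-nitrophenyl on a carbonyl carbon. Among the measured compounds shown here, no measured pair of compounds differs in one place only, so the data give no direct guide to the size of this change. With compound 2 at 18000 nM as the only anchor, no change beyond the usual scatter is expected in this assay, in either direction. The expected step is a 1.1-fold higher number from compound 2 to compound 3 (0.05 log units; within the scatter). For compound 3 the estimated value is 20000 nM, with an expected range of 7000 nM to 60000 nM.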

Compound 3, half-maximal cytotoxic concentration: > 100000 nM
Compound 3: a limit, no number; the forecaster's own chance of this, stated with the estimate: 10%; middle value at least 5.0-fold (0.69 log units) from the limit.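

In this assay, the place on the carbonyl carbon proves responsive to where the nitro group sits on the ring: with no atom added or lost, 4-nitrophenyl in place of 3-nitrophenyl gives an at least 5.5-fold higher number from compound 2 to compound 3 (0.74 log units; beyond the scatter). The entry for compound 3, > 100000 nM, is a limit of the assay and not a number. The step therefore fixes only a lower end, and its true size cannot be read from the data shown: the limit of > 100000 nM in this assay, at which 2 of the 3 values shown sit.

Going by these compounds, it remains open how far the number for compound 3 would lie from that of compound 2 in a test reaching higher concentrations. Also open, on these data alone, is what an amine or a carboxylic acid would do in place of the nitro group on this ring, and whether the same change would have a similar effect on a different core.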